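The compounds below may be only part of what the source reports. "The series", "measured", "known", "first", "only" and "open" are said of these compounds alone.

Compound 1 `CCC(C)C(N)c1cc(C(F)(F)F)ccc1N1CCN(C(=O)CCc2ccc(Cl)cc2Cl)CC1` is the starting point here. In an assay on HEK293 cells for displacement of a labelled ligand from Melanocortin receptor 4 (Homo sapiens) (a lower number here means a stronger inhibitor, a higher number a weaker inhibitor), compound 1 gives 160 nM, the lowest of the three numbers measured. Within the data shown here, compound 2 `CC(C)C[C@H](N)c1cc(C(F)(F)F)ccc1N1CCN(C(=O)CCc2ccccc2O)CC1` gives 3300 nM in this assay, and compound 3 `CC(C)C[C@H](N)c1cc(C(F)(F)F)ccc1N1CCN(C(=O)CCc2cccs2)CC1` gives 4600 nM; the only measured step between them, a 1.4-fold higher number from compound 2 to compound 3 (0.14 log units; within the scatter), changes the ring at the far end of the amide chain and leaves the amine end untouched.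

Compound 4 `CCC(C)[C@H](NC[C@@H]1CCCN1)c1cc(C(F)(F)F)ccc1N1CCN(C(=O)CCc2ccc(Cl)cc2Cl)CC1` keeps the whole of compound 1 apart from one change: 2-methyl-1-(((pyrrolidin-2-yl)methyl)amino)butyl in place of 1-amino-2-methylbutyl on an aromatic carbon. The entering group brings one five-membered non-aromatic ring with one hetero atom, two hydrogen-bond donors and two hydrogen-bond acceptors, and two defined stereocentres, while the dichlorophenyl end of the chain stays as in compound 1.

Among the measured compounds shown here, none of the measured steps touches the amine, so nothing measured speaks directly to this change; the step between compound 2 and compound 3 concerns another part of the molecule. The expected step of a 1.6-fold lower number from compound 1 to compound 4 (0.20 log units; within the scatter) is therefore uncertain, with no strong reason to expect a move beyond the scatter in either direction. For compound 4 in this assay a value of about 100 nM is estimated, within a range from 20 nM to 600 nM.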

Compound 4, inhibition constant: 64 nM
Estimate against measurement, compound 4: 1.6-fold (0.19 log units) above; low and high end bracket the measured number.
By their numbers in this assay, from the lowest: compound 4; then compound 1; then compounds 2 and 3 (each within the scatter of the next).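

Among these compounds, this is the first measured change at the amine end of the molecule, the group on an aromatic carbon meta to the trifluoromethyl group, and it moves the number. In this assay, among the compounds shown here, 2-methyl-1-(((pyrrolidin-2-yl)methyl)amino)butyl in place of 1-amino-2-methylbutyl gives a 2.5-fold lower number from compound 1 to compound 4 (0.40 log units; beyond the scatter), a modest step, whereas the one earlier step, at the far end of the amide chain, stayed within the scatter. The result also shows that this position accepts a much larger group carrying a five-membered non-aromatic ring and a second nitrogen without any loss, although the data offer no explanation for the gain.

From the compounds shown here alone, this single step cannot separate what the ring, the second nitrogen and the two defined stereocentres each contribute, so it remains open whether a plain 2-aminoethyl chain on the same nitrogen, or a piperidin-2-ylmethyl group in place of the pyrrolidin-2-ylmethyl group, would give a similar number. Going by these compounds, it is also open whether the same amine change would have a similar effect with the 2-hydroxyphenyl or thiophen-2-yl ring at the far end of the chain.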